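Cytotoxicity: an isopentyl analogue of compound 2

The source may hold more compounds than are shown below. What is called first, only, known or untested is meant among the compounds shown, and "the series" means these compounds.

The measured compounds and their values:
compound 1, `CC(C)Cc1ccc2c(NCCCNCc3ccco3)ccnc2c1`: 16000 nM
compound 2, `COc1cccc(CNCCCNc2ccnc3cc(Oc4ccc(Cl)cc4)ccc23)c1O`: 5700 nM
compound 3, `COc1ccc(F)cc1CNCCCNc1ccnc2cc(C3CCCCC3)ccc12`: 2290 nM

Three compounds sharing a common core were tested in an ADME assay on HepG2 cells (Homo sapiens) for cytotoxicity, read by luminescence, CellTiter-Glo and ATP content, with a stated time of 72 h; a higher number here means that more compound is needed for the effect, a lower number that less compound is needed. Compound 2 sits in the middle of the three: its number is below that of compound 1 and above that of compound 3, and both gaps lie beyond the scatter of this assay.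

The unmeasured compound 4, `COc1cccc(CNCCCNc2ccnc3cc(CCC(C)C)ccc23)c1O`, is derived from compound 2 by a single change, (isopentyl in place of 4-chlorophenoxy on an aromatic carbon). Going by the values given here, no measured pair shows this exact change. The two compounds that carry an alkyl group at the equivalent place point in opposite directions: compound 1 gives 16000 nM, compound 3 gives 2290 nM, and both differ from compound 2 elsewhere as well. On that basis no step beyond the scatter is expected in this assay for the change from compound 2 to compound 4.

Compound 4 is therefore estimated to give 7000 nM in this assay, within a range of 2500 nM to 20000 nM, an expected step of a 1.2-fold higher number from compound 2 to compound 4 (0.09 log units; within the scatter).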

Compound 4, half-maximal effective concentration: 5390 nM
For compound 4 the middle estimate is 1.3-fold (0.11 log units) above the measured one; the range from low to high includes it.
By their numbers in this assay, from the lowest: compound 3; then compounds 4 and 2 (each within the scatter of the next); then compound 1.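

In this assay, going by these compounds alone, the swap of 4-chlorophenoxy for isopentyl on this aromatic carbon gives a 1.1-fold lower number from compound 2 to compound 4 (0.02 log units; within the scatter), the first reading of a change at this position with the rest of compound 2 held fixed. The earlier compounds shown here could not show this, as compound 1 and compound 3 each differ from compound 2 in more than one place. The aromatic ring, the oxygen and the chlorine of 4-chlorophenoxy can therefore all leave without a step beyond the scatter, and nothing available gives a reason for this outcome.

On these data alone, whether an amine, a carboxylic acid or a longer chain at this aromatic carbon would also stay within the scatter remains open. As far as these compounds go, it is also open whether the same swap would give a similar step with the side chains of compound 1 or compound 3.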